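The source may hold more compounds than are shown below. What is called first, only, known or untested is meant among the compounds shown, and "the series" means these compounds.

Compound 3, `CN(CCCNS(=O)(=O)c1cc(C(F)(F)F)cc(C(F)(F)F)c1)Cc1ccccc1`, stands at the high end of the three numbers in hand. In a functional assay on Capan-2 cells (Homo sapiens) for inhibition, read by MTT assay, with a stated time of 72 h (a higher number here means a weaker inhibitor of growth, a lower number a stronger inhibitor of growth), compound 3 gives 46000 nM, the weakest inhibitor of growth among the measured set. Compound 1, `O=S(=O)(NCCCCNCc1ccc(Br)cc1)c1cc(C(F)(F)F)cc(C(F)(F)F)c1`, gives 1900 nM, and compound 2, `O=S(=O)(NCCCNCc1ccc(Cl)c(C(F)(F)F)c1)c1cc(C(F)(F)F)cc(C(F)(F)F)c1`, gives 9100 nM. For the measured compounds named here, the step of a 24-fold higher number from compound 1 to compound 3 (1.38 log units; beyond the scatter) is the only measured step that touches the part of the molecule changed next, and it is large: replacing ((4-bromobenzyl)amino)methyl by benzyl(methyl)amino raised the number well beyond the scatter.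

Compound 4, `O=S(=O)(NCCCNCc1cccc(Cl)c1)c1cc(C(F)(F)F)cc(C(F)(F)F)c1`, differs from compound 3 by (3-chlorobenzyl)amino in place of benzyl(methyl)amino on a saturated chain carbon, three bonds along the chain from a sulfonamide nitrogen. This change partly runs the earlier step back: the amine regains its hydrogen-bond donor and a halogen returns to the aromatic ring, though compound 4 keeps the chain length of compound 3 and compound 2 rather than that of compound 1. Compound 2, which shares that chain length and carries a halogen-bearing benzylamino group, sits between compound 1 and compound 3. On this basis a lower number than compound 3 is expected in this assay, and the expected step of a 5.8-fold lower number from compound 3 to compound 4 (0.76 log units; beyond the scatter) is estimated to be clearly beyond the scatter. Compound 4 is therefore estimated at 8000 nM, with a likely range from 2500 nM to 25000 nM.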

Compound 4, concentration for 50% growth inhibition: 8000 nM
For compound 4 middle estimate and measured number coincide at the digits printed, within the range that was stated.
By their numbers in this assay, from the lowest: compound 1; then compounds 4 and 2 (each within the scatter of the next); then compound 3.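

In this assay, a 5.8-fold lower number from compound 3 to compound 4 (0.76 log units; beyond the scatter) shows that the number responds when (3-chlorobenzyl)amino replaces benzyl(methyl)amino with the chain length held constant, although this single step combines loss of the methyl on the amine with gain of a chlorine on the ring. The substitution of 3-chlorophenyl for 4-chloro-3-(trifluoromethyl)phenyl gives a 1.1-fold lower number from compound 2 to compound 4 (0.06 log units; within the scatter), so this pair does not distinguish the two aryl groups, and removal of the trifluoromethyl group has no readable effect here. Compound 1 remains apart, with a 4.2-fold higher number from compound 1 to compound 4 (0.62 log units; beyond the scatter) for (3-chlorobenzyl)amino in place of ((4-bromobenzyl)amino)methyl, but that step changes the chain and the halogen-bearing ring together and cannot assign the difference to either one.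

The compounds shown leave open whether the step from compound 3 comes from the methyl or the chlorine, which a plain benzylamino group on the same chain would help to separate, and whether a 3-chlorobenzyl group on the longer chain of compound 1 would match that compound. No evidence is given that explains any of these differences.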